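The compounds below may be only part of what the source reports. "The series", "measured", "known", "first", "only" and "open" are said of these compounds alone.

Measured compounds:
compound 1, `CN1CCN(CCCN(C[C@H]2Cc3ccccc3CN2)[C@H]2CCCc3cccnc32)CC1`, 360 nm/s
compound 2, `c1cnc(CN(CCCN2CCNCC2)[C@H]2CCCc3cccnc32)nc1`, 31 nm/s
compound 3, `c1cnc2c(c1)CCC[C@@H]2N(CCCN1CCNCC1)Cc1nc2ccccc2s1`, no result reported

In an ADME assay for permeability, using PAMPA, with a stated time of 4 h, at pH 7.4 (on this read-out lower numbers stand for lower permeability and higher numbers for higher permeability), compound 1 gives 360 nm/s and compound 2 gives 31 nm/s; the two values show compound 1 well above compound 2. Compound 3, whose structure is `c1cnc2c(c1)CCC[C@@H]2N(CCCN1CCNCC1)Cc1nc2ccccc2s1`, stands nowhere on these numbers: in this assay compound 3 gives "not determined" (no result reported), so it offers no anchor of its own. The step to compound 4, `c1ccc2c(c1)CN[C@H](CN(CCCN1CCNCC1)[C@H]1CCCc3cccnc31)C2`, is described by 1,2,3,4-tetrahydroisoquinolin-3-yl in place of 1,3-benzothiazol-2-yl on a saturated chain carbon bound to an amine nitrogen. Since compound 3 carries no number, the size of this step in this assay cannot be drawn from any measured pair, and the account can only set an expectation for compound 4 directly from compound 1 and compound 2. Compound 4 shares the 1,2,3,4-tetrahydroisoquinolin-3-yl group with compound 1 and the remainder of its chain with compound 2, so its reading is expected to fall between the values of those two: compound 1 gives 360 nm/s and compound 2 gives 31 nm/s. On that basis compound 4 is estimated at 110 nm/s in this assay, with an expected range from 35 nm/s to 330 nm/s.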

Compound 4, apparent permeability: 16 nm/s
Estimate against measurement, compound 4: 6.9-fold (0.84 log units) above; the measured number lies below the stated range.
By their numbers in this assay, from the lowest: compounds 4 and 2 (each within the scatter of the next); then compound 1.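

In this assay, the change at the saturated chain carbon bound to an amine nitrogen now has its first readable step, a 1.9-fold lower number from compound 2 to compound 4 (0.29 log units; within the scatter), so pyrimidin-2-yl and 1,2,3,4-tetrahydroisoquinolin-3-yl are not told apart at this place on this read-out. The 1,2,3,4-tetrahydroisoquinolin-3-yl group alone does not go with a high number in this assay: compound 1, which also carries it, gives 360 nm/s, while compound 4 gives 16 nm/s, so the printed values place the two compounds well apart despite the shared group. No measurement at hand accounts for either the closeness of the first pair or the distance of the second.

The step from 1,3-benzothiazol-2-yl to 1,2,3,4-tetrahydroisoquinolin-3-yl cannot be read, as compound 3 has no number in this assay. As far as these compounds go, it also remains open how a phenyl or a pyridin-2-yl group would read at this place, and whether an acetyl group on the ring nitrogen of the 1,2,3,4-tetrahydroisoquinolin-3-yl group would shift the value of compound 4.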